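The source may hold more compounds than are shown below. What is called first, only, known or untested is meant among the compounds shown, and "the series" means these compounds.

Measured in this series:
Compound 1 `CCc1ccccc1/C=C/C(=O)c1c(O)cc(OC)cc1OC`: 2500 nM
Compound 2 `COc1cc(O)c(C(=O)/C=C/c2ccc(O)c(O)c2)c(OC)c1`: 31600 nM
Compound 3 `COc1cccc(/C=C/C(=O)c2c(O)cc(OC)cc2OC)c1`: 3100 nM

In a functional assay on B16-F10 cells (Mus musculus) for inhibition, with a stated time of 4 days (on this read-out lower numbers stand for stronger inhibition and higher numbers for weaker inhibition), compound 1 gives the lowest of the three numbers. Compound 3 sits close to it, within the scatter, so no order can be read between those two; compound 2 gives a clearly higher number, beyond the scatter.

Compound 4 `COc1cc(O)c(C(=O)/C=C/c2ccccc2C)c(OC)c1` has not yet been measured. It differs from compound 1 by hydrogen in place of methyl on a saturated chain carbon bound to an aromatic carbon. Among the compounds with values here, no measured pair shows this change, so nothing in the data points either way. Because compound 1 gives 2500 nM and the change is a single carbon on a chain, the step of a 1.1-fold higher number from compound 1 to compound 4 (0.05 log units; within the scatter) is expected to stay within the scatter. Compound 4 is therefore estimated at 2800 nM, between 1200 nM and 6500 nM.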

Compound 4, half-maximal inhibitory concentration: 3000 nM
For compound 4 the middle estimate is 1.1-fold (0.03 log units) below the measured one; measured number inside the range.
By their numbers in this assay, from the lowest: compounds 1, 4 and 3 (each within the scatter of the next); then compound 2.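

Compounds 1 and 4 form the series' first pair that differs in one place, and the change from ethyl to methyl gives a 1.2-fold higher number from compound 1 to compound 4 (0.08 log units; within the scatter) in this assay. The two compounds therefore cannot be told apart, so on this saturated chain carbon bound to an aromatic carbon, losing that one carbon leaves no readable mark on this read-out. Nothing available bears on why this is so.

From the compounds shown here alone, what stays open is whether a longer chain such as propyl would also go unnoticed here. An amine or a carboxylic acid at this place is equally untested by the compounds shown.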